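Methoxyphenyl shift in the hydroxamic acid series

The source may report more compounds than this note shows. Statements on the series, on what has been measured and on what is new or still open speak of the compounds shown alone.

Measured so far in a functional assay on HCT-116 cells (Homo sapiens) for antiproliferative activity, read by sulforhodamine B assay, with a stated time of 48 h (on this read-out lower numbers stand for stronger inhibition of growth and higher numbers for weaker inhibition of growth), are these two compounds:
- compound 1 `COc1ccc(C(=O)c2ccc3nc(/C=C/C(=O)NO)ccc3c2)cc1OC` gives 1780 nM here
- compound 2 `COc1cccc(Oc2ccc3nc(/C=C/C(=O)NO)ccc3c2)c1` gives 2740 nM here

On these numbers, compound 2 stands level with compound 1, since the two values lie within the scatter of each other. Compound 3 `COc1ccc(Oc2ccc3nc(/C=C/C(=O)NO)ccc3c2)cc1` awaits measurement and differs from compound 2 by one change: 4-methoxyphenyl in place of 3-methoxyphenyl on an oxygen on an aromatic ring. For the measured compounds named here, no measured pair shows a step of this kind, so no change beyond the scatter is expected in this assay, in either direction. The expectation therefore starts from compound 2 at 2740 nM as its anchor. The estimated step of a 1.1-fold lower number from compound 2 to compound 3 (0.06 log units; within the scatter) is expected to stay within the scatter. Compound 3 is expected near 2400 nM, with an estimated range from 1000 nM to 6000 nM in this measurement.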

Compound 3, concentration for 50% growth inhibition: 1820 nM
For compound 3 the middle estimate is 1.3-fold (0.12 log units) above the measured one; the range from low to high includes it.
By their numbers in this assay, from the lowest: compounds 1, 3 and 2 (each within the scatter of the next).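

In this assay, for the compounds shown here, 4-methoxyphenyl in place of 3-methoxyphenyl on an oxygen on an aromatic ring gives a 1.5-fold lower number from compound 2 to compound 3 (0.18 log units; within the scatter) and so provides the first step that can be read at one place. With the same atoms joined differently, the two methoxyphenyl compounds stand level, so this assay does not separate the two groups at this position. No available evidence bears on this result.

Still open, on these data alone, is whether any change at this position can produce a step beyond the scatter, for instance a carboxylic acid or an amine on the phenyl ring in place of the methoxy group. The compounds shown also leave open whether the level standing of compound 2 and compound 3 extends to a phenyl ring with no methoxy group.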